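Swapping isopropyl for bromo in a macrophage toxicity series

The compounds below may be only part of what the source reports. "The series", "measured", "known", "first", "only" and "open" are said of these compounds alone.

Measured compounds:
- compound 1 `O=C1CC(c2ccc(Br)cc2)Oc2cc(OCc3cn(Cc4ccc(Br)cc4)nn3)ccc21`: 87500 nM
- compound 2 `CCCCCCn1cc(COc2ccc3c(c2)OC(c2ccc(C(C)C)cc2)CC3=O)nn1`: "not determined" (no result reported)

Compound 1 `O=C1CC(c2ccc(Br)cc2)Oc2cc(OCc3cn(Cc4ccc(Br)cc4)nn3)ccc21` was tested in an ADME assay on cells (Macrophage) for cytotoxicity, read by resazurin assay, with a stated time of 48 h (on this read-out higher numbers stand for lower toxicity in this test and lower numbers for higher toxicity in this test), and gives 87500 nM. Compound 2 `CCCCCCn1cc(COc2ccc3c(c2)OC(c2ccc(C(C)C)cc2)CC3=O)nn1` carries a hexyl chain on the triazole instead of the bromobenzyl of compound 1, together with a 4-isopropylphenyl on the shared core; in this assay compound 2 is recorded as "not determined" (no result reported), so it stands nowhere on the numbers shown and gives no anchor of its own.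

Compound 3 `CCCCCCn1cc(COc2ccc3c(c2)OC(c2ccc(Br)cc2)CC3=O)nn1` differs from compound 2 in one place: bromo in place of isopropyl on an aromatic carbon. This brings the 4-bromophenyl of compound 1 back while keeping the hexyl chain of compound 2. Going by the values given here, with no measured step from compound 2, the size and direction of the change in this assay cannot be read from the data; the only reference is compound 1, which also carries the 4-bromophenyl, and a result close to it, within the scatter, seems the likeliest outcome. Compound 3 is therefore expected to give about 80000 nM in this assay, with a range from 30000 nM to 250000 nM.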

Compound 3, half-maximal cytotoxic concentration: 20300 nM
Estimate against measurement, compound 3: 3.9-fold (0.60 log units) above; the whole stated range lies above it.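

In this assay, going by these compounds alone, the one step that can be read lies at the saturated chain carbon bound to an aromatic nitrogen, where pentyl stands in place of 4-bromophenyl and everything else stays the same: a 4.3-fold lower number from compound 1 to compound 3 (0.63 log units; beyond the scatter). This shows that the position is not silent, since changing the group there moves the read-out beyond the usual scatter, towards higher toxicity in this test. Nothing available explains why the pentyl compound sits lower on this read-out.

As far as these compounds go, the swap of isopropyl for bromo cannot be read, since compound 2 has no number, so the effect of the 4-isopropylphenyl to 4-bromophenyl change on macrophage toxicity stays unknown, and the result speaks only to the chain position. From the compounds shown here alone, with a single pair at that position, it also remains open whether a longer chain would push the number lower still, and whether a chain ending in an amine or a carboxylic acid would follow the same direction.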